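A Carbamoyl Group Replaces Tert-Butyl at the Assay Limit

The source may report more compounds than this note shows. Statements on the series, on what has been measured and on what is new or still open speak of the compounds shown alone.

In an ADME assay on HEK293 cells (Homo sapiens) for cytotoxicity, with a stated time of 72 h (a higher number here means that more compound is needed for the effect, a lower number that less compound is needed), compound 2 (`Cc1cc(NC(=O)Nc2ccccc2C(C)(C)C)c2ccccc2n1`) gives > 25000 nM and this is a limit, not a number. Compound 1 (`Cc1cc(NC(=O)Nc2ccccc2OC(F)(F)F)c2ccccc2n1`) gives > 25000 nM and this too is a limit. Compound 3 (`Cc1cc(NC(=O)Nc2ccc(F)cc2)c2ccccc2n1`) gives > 25000 nM and this too is a limit. Among the measured compounds shown here, the whole record in this assay therefore comes down to one observation (the limit of > 25000 nM in this assay, at which 3 of the 3 values shown sit) and no compound yet has a readable number.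

Compound 4 (`Cc1cc(NC(=O)Nc2ccccc2C(N)=O)c2ccccc2n1`) keeps the core of compound 2 and differs in one place, with carbamoyl in place of tert-butyl on an aromatic carbon, ortho to a large group (carbamoyl in place of tert-butyl on an aromatic carbon). For the measured compounds named here, the only measured step that bears on this change is the one where tert-butyl takes the place of trifluoromethoxy (a step that the two limits leave unreadable from compound 1 to compound 2) and it gives no size or direction to carry over. The expected step is a number no higher from compound 2 to compound 4 (the limit leaves the size open) and no change beyond the scatter is estimated. For compound 4 the estimate is 25000 nM with an expected range from 12000 nM to 50000 nM and another report as a limit is expected.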

Compound 4, half-maximal effective concentration: > 25000 nM
Compound 4: a limit, no number; the forecaster's own chance of this, stated with the estimate: 85%; the middle value lies on the limit itself.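

The steps from compound 1 to compound 4 and from compound 2 to compound 4 cannot be read in this assay, where all the compounds share one limit: the limit of > 25000 nM in this assay, at which 4 of the 4 values shown sit.

The compounds shown leave open what concentration of any of them gives the effect, and whether carbamoyl, tert-butyl and trifluoromethoxy differ at all.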